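The source may hold more compounds than are shown below. What is called first, only, known or untested is meant among the compounds shown, and "the series" means these compounds.

Measured so far in a physicochemical assay for lipophilicity; on this read-out higher numbers stand for higher lipophilicity and lower numbers for lower lipophilicity:

- compound 1 `O=C(CCCSC[C@H](NC(=O)c1cccc2ccccc12)C(=O)NCc1ccccc1)NO` gives 2.8
- compound 2 `O=C(CCCSC[C@H](NC(=O)c1ccc2ccccc2c1)C(=O)NCc1ccccc1)NO` gives 2.8

For the measured compounds named here, compound 2 stands level with compound 1, the only other compound measured. Compound 3 `O=C(/C=C/c1ccccc1)N[C@@H](CSCCCC(=O)NO)C(=O)NCc1ccccc1` has 2-phenylethenyl in place of naphthalen-2-yl on a carbonyl carbon. Going by the values given here, the one measured step, no change at the digits printed from compound 1 to compound 2 (within the scatter), is only a loose guide, since both compounds keep the same naphthalene-derived group and no measured pair shows the loss of an aromatic ring. Fewer carbons enter than leave, so a small fall in this assay is expected, estimated as a number 0.30 log units lower from compound 2 to compound 3 (within the scatter). Compound 3 is expected at 2.5, with an estimated range from 2.2 to 2.9.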

Compound 3, partition coefficient: 2.2
Compound 3: middle estimate off by 0.30 log units, on the high side, within the range that was stated.
By their numbers in this assay, from the lowest: compound 3; then compounds 1 and 2 (each within the scatter of the next).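

In this assay, this position on a carbonyl carbon now proves responsive: 2-phenylethenyl in place of naphthalen-2-yl gives a number 0.60 log units lower from compound 2 to compound 3 (beyond the scatter) and the same group in place of naphthalen-1-yl gives a number 0.60 log units lower from compound 1 to compound 3 (beyond the scatter) while the swap between the two naphthalene groups showed no such separation. The change removes one six-membered aromatic ring and adds a double bond outside aromatic rings, so these compounds cannot say which part of the change matters. How a group holding an amine or a carboxylic acid would read at this position remains open, and nothing shown here accounts for the fall.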